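The compounds below may be only part of what the source reports. "The series", "measured", "known", "first", "only" and "open" are said of these compounds alone.

Three compounds sharing one core were tested in a functional assay on OVCAR-3 cells (Homo sapiens) for inhibition; a lower number here means a stronger inhibitor, a higher number a weaker inhibitor. Compound 1 `CCCCNC(=O)N1CC1C#N` gives 12000 nM. Compound 2 `N#CC1CN1C(=O)Nc1ccccc1` gives 6800 nM, and compound 3 `N#CC1CN1C(=O)NC1CCCCC1` gives 31000 nM. Among these three numbers compound 1 stands second highest; its nearest neighbour is compound 2, a gap that lies within the scatter of repeated measurements, while compound 3 lies furthest from it and beyond that scatter. Compound 4 `CCNC(=O)N1CC1C#N` has not yet been measured in this assay. It differs from compound 1 in one place: hydrogen in place of ethyl on a saturated chain carbon, two bonds along the chain from an amide-type nitrogen. Among the measured compounds shown here, no pair of measured compounds shows what this change does, so the expectation rests on the three values alone: the measured compounds differ only in what sits outside the shared core, and their numbers span a modest range. The shortening of the chain is therefore expected to move the number only slightly, if at all, with a somewhat weaker inhibitor a little more likely than a stronger one, so that the step from compound 1 to compound 4 is expected to come out as a 1.5-fold higher number from compound 1 to compound 4 (0.18 log units; within the scatter). On this basis compound 4 is expected to give about 18000 nM in this assay, within a range from 7000 nM to 45000 nM.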

Compound 4, half-maximal inhibitory concentration: 14000 nM
Compound 4: middle estimate off by 1.3-fold (0.11 log units), on the high side, and the stated range covers the measured number.
By their numbers in this assay, from the lowest: compounds 2, 1 and 4 (each within the scatter of the next, the first and the last beyond it); then compound 3.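

In this assay, the step from butyl to ethyl, hydrogen in place of ethyl on a saturated chain carbon, two bonds along the chain from an amide-type nitrogen, comes out as a 1.2-fold higher number from compound 1 to compound 4 (0.07 log units; within the scatter), the first direct reading of any single change among these compounds. This step lies within the scatter, so the butyl chain of compound 1 and the ethyl chain of compound 4 cannot be told apart in this assay, and at this position the two carbon atoms that leave make no measurable difference to the number. Nothing measured alongside these values accounts for this result.

The compounds shown leave open whether the number would also hold for a methyl chain or a longer chain such as hexyl in the same place, since a single step cannot show how far this tolerance extends. They also leave open what a chain carrying an amine or a carboxylic acid would do, as every chain here is plain carbon.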